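Replacing the Nitro Group of Compound 1

The source may hold more compounds than are shown below. What is called first, only, known or untested is meant among the compounds shown, and "the series" means these compounds.

For the measured compounds named here, in a functional assay on QG-56 cells (Homo sapiens) for antiproliferative activity (a lower number here means a stronger inhibitor, a higher number a weaker inhibitor), compound 1 (`COc1cccc(-c2cc([N+](=O)[O-])cc3cc(C(O)(c4ccc(C#N)cc4)c4cncn4C)oc23)c1`) gives 38.8 nM and holds the lower of the two numbers so far, while compound 2 (`Cn1cncc1C(O)(c1ccc(C#N)cc1)c1cc2cc([N+](=O)[O-])cc(-c3ccc(F)cc3)c2o1`) gives 158 nM in the same test. Compound 3 (`COc1cccc(-c2cc(CN(C)C)cc3cc(C(O)(c4ccc(C#N)cc4)c4cncn4C)oc23)c1`) keeps the 3-methoxyphenyl group of compound 1 but carries (dimethylamino)methyl in place of nitro on an aromatic carbon. Going by the values given here, only one measured step exists (a 4.1-fold higher number from compound 1 to compound 2 (0.61 log units; beyond the scatter)), and it swaps 3-methoxyphenyl for 4-fluorophenyl at a different place, so it bears on this change only loosely, as a guide to size. Among the compounds with values here, no measured compound shows what replacing nitro does. A modest step to a higher number in this assay is expected, with wide uncertainty. The estimated change is (a 2.1-fold higher number from compound 1 to compound 3 (0.31 log units; beyond the scatter)) for this swap. Compound 3 is expected at 80 nM with an estimated range of 15 nM to 400 nM around that figure.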

Compound 3, half-maximal inhibitory concentration: 142 nM
Beside the measured number, compound 3's estimate is 1.8-fold (0.25 log units) below it, within the range that was stated.
By their numbers in this assay, from the lowest: compound 1; then compounds 3 and 2 (each within the scatter of the next).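

The nitro group of compound 1 is not essential for activity on these cells: with (dimethylamino)methyl on the same aromatic carbon, this assay shows a 3.7-fold higher number from compound 1 to compound 3 (0.56 log units; beyond the scatter). This is a real but modest loss, so this position accepts a group that shares no heavy atom count with nitro, has no double bond outside aromatic rings and has one hydrogen-bond acceptor rather than two. No measurement of any property of these groups is at hand to explain the size of this step.

A single replacement cannot separate what is lost with nitro from what is gained with the amine, so a plain hydrogen, a methyl or a nitrile at this carbon would be informative. Going by these compounds, it also remains open whether a carboxylic acid or a longer aminoalkyl chain here would give a higher or lower number.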